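A few compounds are considered here, and "the series" means these few. Any claim that something is new, unique, unknown or untested is made for them only; others in the source may bear on it.

Of the compounds shown here, three have been measured so far. Compound 1 has the structure `O=C(OCc1ccccc1)[C@@H]1COC(c2ccccc2)=N1`, and in a physicochemical assay for metabolic stability, read by LC-MS, in simulated gastric fluid, with a stated time of 15 min, tested at 50 uM (on this read-out higher numbers stand for a more stable compound and lower numbers for a less stable compound), compound 1 gives 1.7%. Compound 2, with the structure `O=C(OCc1ccccc1)c1coc(-c2ccccc2)n1`, gives 1.8% in this assay. The two share the same ester part, but how the two cores differ is not broken down here. Compound 3, with the structure `O=C(OCc1ccccc1)c1coc(-c2ccccc2OCc2ccccc2)n1`, carries one more group than compound 2, namely (benzyloxy in place of hydrogen on an aromatic carbon). In this assay compound 3 gives 2.9%. The step of a number 1.1 percentage points higher from compound 2 to compound 3 (within the scatter) is small, so the two numbers are essentially the same within the usual spread of such measurements.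

Compound 4, with the structure `O=C(OCc1ccccc1)[C@@H]1COC(c2ccccc2OCc2ccccc2)=N1`, has not yet been measured. It relates to compound 1 as compound 3 relates to compound 2: the change is benzyloxy in place of hydrogen on an aromatic carbon, made at the same kind of position and so the same change as before. Because the earlier step of a number 1.1 percentage points higher from compound 2 to compound 3 (within the scatter) stayed within the scatter, the step from compound 1 to compound 4 is expected to be similarly small, about a number 1.1 percentage points higher from compound 1 to compound 4 (within the scatter) in this assay. Compound 4 is therefore estimated to give 2.8% in this assay, with a likely range from 0.5% to 6%.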

Compound 4, percent of the compound remaining: 0.8%
Compound 4: the middle estimate sits 2 percentage points above what was measured; the measured number falls inside the stated range.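

In this assay, placing benzyloxy on the aromatic ring gives a number 0.9 percentage points lower from compound 1 to compound 4 (within the scatter), and on the other core the same change gave a number 1.1 percentage points higher from compound 2 to compound 3 (within the scatter), so neither core shows a step that can be told apart from repeat-measurement noise. Within the data shown here, this shows that, for these two pairs and in this one read-out, the change carries from one core to the other in a limited sense: it leaves the number essentially unchanged both times, although that is a result from only two cores, one position and one assay, and it does not show that benzyloxy would be as silent on other cores, at other places on the ring, or in other tests. Nothing measured here offers an explanation for the result.

As far as these compounds go, all four compounds keep the same benzyl ester and differ only in the core and in hydrogen or benzyloxy on the ring, so the effect of an amide in place of that ester remains open. Also open, from the compounds shown here alone, is whether a different group on the same ring, such as an amine or a carboxylic acid, would produce a step beyond the scatter.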